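The compounds below may be only part of what the source reports. "The series", "measured", "known", "first", "only" and "open" are said of these compounds alone.

Compound 1 `COc1ccc(-c2cnc(NC(=O)C3CCCCC3)n2C)cc1`: in a toxicity assay on THP-1 cells (Homo sapiens) for inhibition (on this read-out lower numbers stand for higher toxicity in this test and higher numbers for lower toxicity in this test), compound 1 gives > 100000 nM, which is a limit of the assay rather than a number.
Compound 2 `COc1ccc(-c2cnc(NC(=O)c3cccc([N+](=O)[O-])c3)n2C)cc1`: in this assay compound 2 gives > 100000 nM, again only a limit.
Compound 3 `CCC(=O)Nc1ncc(-c2ccc(OC)cc2)n1C`: in this assay compound 3 gives > 100000 nM, also a limit.

Going by the values given here, compound 3 thus stands where every value so far stands, at the limit of the assay (the limit of > 100000 nM in this assay, at which 3 of the 3 values shown sit), and no number is known for it. Among the compounds with values here, the only measured change at the carbonyl carbon is a step that the two limits leave unreadable from compound 1 to compound 3, and because both of its compounds sit at the limit of > 100000 nM in this assay, at which 3 of the 3 values shown sit, its size cannot be read.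

Compound 4 `COc1ccc(-c2cnc(NC(=O)c3cccc(F)c3)n2C)cc1` differs from compound 3 in one place: 3-fluorophenyl in place of ethyl on a carbonyl carbon. Within the data shown here, one measured step bears on this change, the step from compound 1 to compound 3, and it is unreadable. Compound 2, which also carries an aromatic ring on the carbonyl carbon, shows nothing more than a limit. No step beyond the scatter can therefore be expected for a number no higher from compound 3 to compound 4 (the limit leaves the size open), and the expectation is that compound 4 will again be reported only as a limit. Compound 4 is estimated in this assay at 100000 nM, with a range from 50000 nM to 200000 nM.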

Compound 4, half-maximal cytotoxic concentration: > 100000 nM
Compound 4 was reported as a limit; the forecaster's own chance of this, stated with the estimate: 85%; the middle value lies on the limit itself.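

In this assay compound 4 gives > 100000 nM and this is again only a limit. The steps from compound 1, compound 2 and compound 3 to compound 4 cannot be read, because all four compounds sit at the same limit: the limit of > 100000 nM in this assay, at which 4 of the 4 values shown sit.
The compounds shown leave open whether any change on the carbonyl carbon can shift the result in this assay, as none of them yields an actual number.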